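This account rests on a few compounds, and the source may have more. Where it says the series, first, only, none or still open, it means among the compounds named here.

Measured so far in a functional assay on SiHa cells (Homo sapiens) for antiproliferative activity, read by CCK-8 assay, with a stated time of 72 h; a higher number here means a weaker inhibitor, a lower number a stronger inhibitor:
Compound 1 `COc1ccc(-c2cncnc2-c2cc(OC)c(OC)c(OC)c2)cc1O`: 2750 nM
Compound 2 `CCOC(=O)Oc1cc(-c2cncnc2-c2cc(OC)c(OC)c(OC)c2)ccc1OC`: 1890 nM
Compound 3 `COc1ccc(-c2cncnc2-c2cc(OC)c(OC)c(OC)c2)cc1Cl`: 1330 nM

All three carry the same core and differ in one place, and their values lie close together. Compound 3 is separated from only one of the others, by a modest step with chloro in place of hydroxy: a 2.1-fold lower number from compound 1 to compound 3 (0.32 log units; beyond the scatter). Set against the ethoxycarbonyl derivative, it shows no real separation: a 1.4-fold lower number from compound 2 to compound 3 (0.15 log units; within the scatter). The remaining step, a 1.5-fold lower number from compound 1 to compound 2 (0.16 log units; within the scatter), also stays inside the scatter.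

Compound 4 `COc1ccc(-c2cncnc2-c2cc(OC)c(OC)c(OC)c2)nc1` departs further from compound 3: 5-methoxypyridin-2-yl in place of 3-chloro-4-methoxyphenyl on an aromatic carbon. The chloro is gone, and the ring now holds a hetero atom. The measured steps bear on this only in part. Going by the values given here, they change a single substituent on an all-carbon ring, and no measured compound shows a ring exchange. Among the compounds with values here, the one step beyond the scatter, a 2.1-fold lower number from compound 1 to compound 3 (0.32 log units; beyond the scatter), suggests that losing the chloro could cost a little, so a modest rise in the number is expected in this assay, with wide uncertainty. The expected change is a 2.6-fold higher number from compound 3 to compound 4 (0.42 log units; beyond the scatter). Compound 4 is estimated at 3500 nM, with an expected range from 1200 nM to 12000 nM.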

Compound 4, half-maximal inhibitory concentration: 1750 nM
For compound 4 the middle estimate is 2.0-fold (0.30 log units) above the measured one; the range from low to high includes it.
By their numbers in this assay, from the lowest: compounds 3, 4, 2 and 1 (each within the scatter of the next, the first and the last beyond it).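

In this assay, replacing the whole 3-chloro-4-methoxyphenyl with 5-methoxypyridin-2-yl, at this place ortho to a large group, brings no separation (a 1.3-fold higher number from compound 3 to compound 4 (0.12 log units; within the scatter)), so among the compounds shown, this position tolerates a ring with a hetero atom as well as the single-substituent changes on an all-carbon ring seen earlier. Compound 4 also stays within the scatter of the hydroxy compound (a 1.6-fold lower number from compound 1 to compound 4 (0.20 log units; within the scatter)), so it loses the chloro without taking on the separation from compound 3 that compound 1 shows, and it sits within the scatter of both ends of the series. Nothing available here explains why the exchange leaves the number so little changed.

The two changes come together in compound 4, so the compounds shown leave open how much of the step belongs to the ring nitrogen and how much to the loss of the chloro. They also leave open whether a different kind of group on this ring, such as an amino group or an ethoxy in place of the methoxy, would move the number beyond the scatter.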